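The source may report more compounds than this note shows. Statements on the series, on what has been measured and on what is new or still open speak of the compounds shown alone.

Three compounds share a core in which a lactone carries two benzyl ether groups and a side chain ending in a triazole that bears an aryl group. Compound 1 `O=C1O/C(=C\Cn2cc(-c3ccc(Br)cc3)nn2)C(OCc2ccccc2)=C1OCc1ccccc1` links the triazole through a double bond. In a functional assay on MCF7 cells (Homo sapiens) for antiproliferative activity, read by MTT assay, with a stated time of 72 h (on this read-out lower numbers stand for stronger inhibition and higher numbers for weaker inhibition), compound 1 gives > 100000 nM, which is a limit of the assay rather than a number. On the numbers shown, compound 1 stands at the limit of > 100000 nM in this assay, at which 1 of the 3 values shown sits, and nowhere else. The two compounds with a saturated, hydroxylated side chain are measured as numbers: compound 2 `O=C1O[C@H]([C@@H](O)Cn2cc(-c3ccc(Br)cc3)nn2)C(OCc2ccccc2)=C1OCc1ccccc1` gives 5620 nM in this assay, and compound 3 `O=C1O[C@H]([C@@H](O)Cn2cc(-c3cc(C(F)(F)F)cc(C(F)(F)F)c3)nn2)C(OCc2ccccc2)=C1OCc1ccccc1` gives 45900 nM in this assay. Compound 4 `Cc1ccc(-c2cn(C/C=C3\OC(=O)C(OCc4ccccc4)=C3OCc3ccccc3)nn2)cc1` differs from compound 1 in one place: methyl in place of bromo on an aromatic carbon. For the measured compounds named here, no measured pair shows what this exchange does, and the double-bond side chain of compound 1 is only known as a limit. The step from compound 1 to compound 4 is therefore expected to be a number no higher from compound 1 to compound 4 (the limit leaves the size open), with nothing suggesting a move beyond the scatter. Compound 4 is expected to give about 100000 nM in this assay, within 30000 nM to 300000 nM.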

Compound 4, half-maximal inhibitory concentration: > 100000 nM
Compound 4: a limit, no number (the forecaster's own chance of this, stated with the estimate: 70%); the middle value lies on the limit itself.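

Compound 1 and compound 4 each give only a limit of the assay rather than a number, so no step can be read between them. The compounds shown leave open what methyl in place of bromo does to activity, with either the double-bond or the hydroxylated side chain.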